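The source may hold more compounds than are shown below. What is called first, only, known or untested is meant among the compounds shown, and "the series" means these compounds.

Compound 1 `Cc1ccn(Cc2c(F)cccc2F)c2nc(-c3c(F)cccc3F)nc1-2`: in an ADME assay on MDBK cells (Bos taurus) for cytotoxicity (on this read-out higher numbers stand for lower toxicity in this test and lower numbers for higher toxicity in this test), compound 1 gives > 100000 nM, which is a limit of the assay.
Compound 2 `Cc1cccc(Cn2ccc3nc(-c4ccccc4)nc-3c2)c1`: in this assay compound 2 gives > 100000 nM, also a limit.
Compound 3 `Fc1ccccc1Cn1ccc2nc(-c3ccccc3)nc-2c1`: in this assay compound 3 gives > 100000 nM, again a limit.

Compound 2 thus stands only at a limit, with no number of its own, and the limit of > 100000 nM in this assay, at which 3 of the 3 values shown sit, holds every measured compound. Compound 4 `Brc1ccccc1Cn1ccc2nc(-c3ccccc3)nc-2c1` is not yet measured and differs from compound 2 in one place: 2-bromophenyl in place of 3-methylphenyl on a saturated chain carbon bound to an aromatic nitrogen. Among the measured compounds shown here, the one measured step at this place is a step that the two limits leave unreadable from compound 2 to compound 3, and because the limit of > 100000 nM in this assay, at which 3 of the 3 values shown sit, no size could be read from it. No readable step in this assay is expected from compound 2 to compound 4. The estimated step of a number no higher from compound 2 to compound 4 (the limit leaves the size open) means staying at the limit. For compound 4 the expected value is 100000 nM, in a range from 40000 nM to 300000 nM.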

Compound 4, half-maximal cytotoxic concentration: > 100000 nM
Compound 4 was reported as a limit; the forecaster's own chance of this, stated with the estimate: 85%; the middle value sits exactly at the limit.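

Compound 4 gives only a limit in this assay, as do compound 2 and compound 3, so no step among them can be read: the limit of > 100000 nM in this assay, at which 4 of the 4 values shown sit.

The concentration at which any of these compounds would become toxic to the cells remains open.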